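Cytotoxicity notes on a diarylpyrimidine series: cyano placement

The source may hold more compounds than are shown below. What is called first, only, known or untested is meant among the compounds shown, and "the series" means these compounds.

Measured compounds:
- compound 1, `Cc1cc(-c2ccc(C#N)cc2)cc(C)c1Nc1ccnc(Nc2ccc(C#N)cc2)n1`
- compound 2, `Cc1cc(-c2ccccc2)cc(C)c1Nc1ccnc(Nc2ccc(C#N)cc2)n1`

In an ADME assay on MT4 cells (Homo sapiens) for cytotoxicity, read by MTT assay, with a stated time of 4 days (on this read-out lower numbers stand for higher toxicity in this test and higher numbers for lower toxicity in this test), compound 1 gives 2080 nM. In the same test compound 2 gives 4170 nM. Among the compounds with values here, compound 2 has the highest of the two numbers measured so far; its nearest neighbour is compound 1, and the gap between them is a 2.0-fold higher number from compound 1 to compound 2 (0.30 log units; within the scatter), within the scatter.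

Compound 3, `Cc1cc(-c2cccc(C#N)c2)cc(C)c1Nc1ccnc(Nc2ccc(C#N)cc2)n1`, has not yet been measured. It differs from compound 2 by cyano in place of hydrogen on an aromatic carbon. Within the data shown here, the only measured step that bears on it is the removal of a cyano group from compound 1 to compound 2, which gave a 2.0-fold higher number from compound 1 to compound 2 (0.30 log units; within the scatter), within the scatter. Returning a cyano group to that ring, now meta to a large group, is therefore expected to move the number by at most a similar amount, if at all; the expected step is a 1.5-fold lower number from compound 2 to compound 3 (0.17 log units; within the scatter). On that basis compound 3 is estimated at 2800 nM, with a range from 1100 nM to 7000 nM, and a result indistinguishable from compound 2 within the scatter would not be surprising.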

Compound 3, half-maximal cytotoxic concentration: 920 nM
For compound 3 the middle estimate is 3.0-fold (0.48 log units) above the measured one; measured number below the stated range.
By their numbers in this assay, from the lowest: compound 3; then compounds 1 and 2 (each within the scatter of the next).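

Working note: in this assay, a cyano group on this ring is not neutral in every placement. Meta to a large group, it gives a 4.5-fold lower number from compound 2 to compound 3 (0.66 log units; beyond the scatter), whereas the step between compound 1 and compound 2, involving 4-cyanophenyl, stayed within the scatter. The placement of the group therefore counts, since 3-cyanophenyl in place of 4-cyanophenyl gives a 2.3-fold lower number from compound 1 to compound 3 (0.35 log units; beyond the scatter), and nothing available here explains this difference.

Still open, going by these compounds, is whether this shift belongs to cyano itself or would also follow from another group in the same place, such as an amine, a carboxylic acid or a methoxy group. The compounds shown also leave open whether the step would keep its size if the other nitrile, on the far side of the shared core, were replaced by an amide.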